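A few compounds are considered here, and "the series" means these few. Any claim that something is new, unique, unknown or untested is made for them only; others in the source may bear on it.

Three compounds share one core and differ only in the group on a saturated chain carbon bound to a sulfur. In a functional assay on the whole organism (strain NMRI) with Mus musculus as the target, with a stated time of 60 min, at a dose of 20 mg/kg by the intraperitoneal route (a lower number here means a weaker effect, a higher number a stronger effect of the compound at the dose given), compound 1 `CSc1nnc(Cc2ccccc2Oc2ccccc2)[nH]1` gives 147%, compound 2 `CCSc1nnc(Cc2ccccc2Oc2ccccc2)[nH]1` gives 169%, and compound 3 `CCCSc1nnc(Cc2ccccc2Oc2ccccc2)[nH]1` gives 158%, the second highest of the three numbers. Growing the chain gave only modest steps: a number 22 percentage points higher from compound 1 to compound 2 (beyond the scatter), a number 11 percentage points higher from compound 1 to compound 3 (beyond the scatter) and a number 11 percentage points lower from compound 2 to compound 3 (beyond the scatter). Compound 4 `c1ccc(CSc2nnc(Cc3ccccc3Oc3ccccc3)[nH]2)cc1` makes a larger change at the same place: phenyl in place of ethyl on a saturated chain carbon bound to a sulfur. Among the compounds with values here, no measured step exchanges a chain for a ring, so the three small steps suggest only that changes here move the activity little in either direction. The step expected is a number 3 percentage points lower from compound 3 to compound 4 (within the scatter). Compound 4 is therefore estimated at 155%, with a range from 120% to 190%.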

Compound 4, a percentage reported as activity, at one dose (the size of the read-out at that dose, not a potency): 143%
Compound 4: the middle estimate sits 12 percentage points above what was measured; the range from low to high includes it.
By their numbers in this assay, from the lowest: compounds 4 and 1 (each within the scatter of the next); then compound 3; then compound 2.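

In this assay, phenyl on a saturated chain carbon bound to a sulfur gives a number 15 percentage points lower from compound 3 to compound 4 (beyond the scatter) and a number 26 percentage points lower from compound 2 to compound 4 (beyond the scatter), so this ring does not keep the higher numbers seen with the two short chains. Set against the hydrogen at this place, it gives a number 4 percentage points lower from compound 1 to compound 4 (within the scatter), so a six-membered aromatic ring here still leaves a clear effect at the dose given. Nothing available explains these differences.

As far as these compounds go, it remains open how a longer chain such as butyl, or a saturated ring such as cyclohexyl, would behave at this place. Equally open, from the compounds shown here alone, is whether an amine or a carboxylic acid on the phenyl would shift the number.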